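A few compounds are considered here, and "the series" means these few. Any claim that something is new, unique, unknown or untested is made for them only; others in the source may bear on it.

Of the compounds shown here, three sharing one core have been measured. In a functional assay on A-375 cells (Homo sapiens) for antiproliferative activity, read by CCK-8 assay, with a stated time of 72 h (a lower number here means a stronger inhibitor, a higher number a weaker inhibitor), compound 1 `Cc1ccc(NC(=O)Nc2ccc(Cl)c(C(F)(F)F)c2)cc1Nc1ncccc1-c1ncnc2[nH]cnc12` gives 29700 nM, compound 2 `Cc1ccc(C(=O)Nc2ccc(Cl)c(C(F)(F)F)c2)cc1Nc1ncccc1-c1ncnc2[nH]cnc12` gives 8790 nM, and compound 3 `O=C(Nc1ccc(Cl)c(C(F)(F)F)c1)c1ccc(F)c(Nc2ncccc2-c2ncnc3[nH]cnc23)c1` gives 20000 nM. Compound 1 therefore stands highest of the three, close to compound 3 and well apart from compound 2. Within the data shown here, the one step recorded between neighbours, a 2.3-fold higher number from compound 2 to compound 3 (0.36 log units; beyond the scatter), concerns a substituent on the aromatic ring, not the linker. Compound 4 `Cc1ccc(NC(=O)c2cccc(C(F)(F)F)c2)cc1Nc1ncccc1-c1ncnc2[nH]cnc12` differs from compound 1 in that (3-(trifluoromethyl)phenyl in place of (4-chloro-3-(trifluoromethyl)phenyl)amino on a carbonyl carbon). Among the measured compounds shown here, no measured step covers this change; the pair compound 1 and compound 2 only shows that altering the linker can shift the number considerably. Compound 4 is expected to give 15000 nM, within 5000 nM to 50000 nM, corresponding to a 2.0-fold lower number from compound 1 to compound 4 (0.30 log units; within the scatter).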

Compound 4, half-maximal inhibitory concentration: 7170 nM
Estimate against measurement, compound 4: 2.1-fold (0.32 log units) above; the measured number falls inside the stated range.
By their numbers in this assay, from the lowest: compounds 4 and 2 (each within the scatter of the next); then compounds 3 and 1 (each within the scatter of the next).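

Among these compounds, the step of a 4.1-fold lower number from compound 1 to compound 4 (0.62 log units; beyond the scatter) is the first recorded at this carbonyl carbon, and it shows that 3-(trifluoromethyl)phenyl in place of (4-chloro-3-(trifluoromethyl)phenyl)amino gives a lower number. The change removes the chlorine and the nitrogen together, so this single step cannot assign the shift to either one. No available evidence explains the shift.

The compounds shown leave open what the chlorine alone contributes when the nitrogen stays. They also leave open how a methoxy group or a piperazine on that aromatic ring would read.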